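Series notes: arylamino in place of aryl on the shared core

The compounds below may be only part of what the source reports. "The series", "measured", "known", "first", "only" and "open" are said of these compounds alone.

Two compounds of the shared core carry measurements in a functional assay on Jurkat cells (Homo sapiens) for antiproliferative activity, read by MTT assay, with a stated time of 72 h; a lower number here means a stronger inhibitor, a higher number a weaker inhibitor. Compound 1 `COc1cc(C(=O)c2sc3ccccc3c2-c2ccc(Cl)cc2)cc(OC)c1OC` gives 3700 nM in this assay. Among the measured compounds shown here, compound 2 `COc1ccc(-c2c(C(=O)c3cc(OC)c(OC)c(OC)c3)sc3ccccc23)c(OC)c1` gives 4000 nM in this assay; it holds the higher of the two numbers, but the single step between them, a 1.1-fold higher number from compound 1 to compound 2 (0.03 log units; within the scatter), lies within the scatter, so no order is claimed between compound 1 and compound 2.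

For the measured compounds named here, compound 3 `COc1ccc(Nc2c(C(=O)c3cc(OC)c(OC)c(OC)c3)sc3ccccc23)cc1` awaits measurement. (4-methoxyphenyl)amino in place of 2,4-dimethoxyphenyl on an aromatic carbon No measured step covers an aryl group giving way to an arylamino group; the only step available, a 1.1-fold higher number from compound 1 to compound 2 (0.03 log units; within the scatter), exchanges one aryl for another and shows no movement beyond the scatter. That step bears only loosely on the present change, as the link to the core is altered here, not only the ring substituents. Going by the values given here, with no precedent for the new link, the expectation is a number close to that of compound 2, and the estimated step of a 1.1-fold lower number from compound 2 to compound 3 (0.06 log units; within the scatter) is expected to sit within the scatter, with a wide range around it. Compound 3 is therefore estimated at 3500 nM in this assay, expected between 900 nM and 14000 nM.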

Compound 3, half-maximal inhibitory concentration: 3500 nM
Compound 3: the middle estimate sits on the measured number at the digits printed, within the range that was stated.
By their numbers in this assay, from the lowest: compounds 3, 1 and 2 (each within the scatter of the next).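

Working from this assay, the change at this aromatic carbon of the five-membered aromatic ring is now more than an exchange of one aryl group for another. With (4-methoxyphenyl)amino in place of 2,4-dimethoxyphenyl the result is a 1.1-fold lower number from compound 2 to compound 3 (0.06 log units; within the scatter), and with (4-methoxyphenyl)amino in place of 4-chlorophenyl it is a 1.1-fold lower number from compound 1 to compound 3 (0.02 log units; within the scatter), so a new link to the core, bringing a hydrogen-bond donor that both aryl groups lack, leaves the number within the scatter of both aryl compounds. No measured data are at hand that would explain this outcome.

Among the compounds shown here, still open is whether any group at this place can move the number beyond the scatter, as every step so far stays within it. A methylamino group or a morpholine in place of the arylamino group would show whether the aromatic ring on the link counts at all, and a carboxylic acid on that ring would test a quite different substituent at the same position.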